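The source may report more compounds than this note shows. Statements on the series, on what has been measured and on what is new or still open speak of the compounds shown alone.

Series values in a functional assay on COLO 205 cells (Homo sapiens) for inhibition, read by sulforhodamine B assay, with a stated time of 48 h, tested at 50 uM; a lower number here means less inhibition of growth, a higher number more inhibition of growth at the concentration tested:
- compound 1 `COc1ccc(/C=C/C(=O)/C=C/c2ccc(OCc3cn(CCCCOc4cc(=O)oc5ccccc45)nn3)c(OC)c2)cc1OC`: 53%
- compound 2 `COc1ccccc1/C=C/C(=O)/C=C/c1ccc(OCc2cn(CCCCOc3cc(=O)oc4ccccc34)nn2)c(OC)c1`: 47%

For the measured compounds named here, compound 2, at 47%, lies within the scatter of compound 1, the only other measured compound, so the two cannot be ranked. The unmeasured compound 3 `COc1cc(/C=C/C(=O)/C=C/c2cccs2)ccc1OCc1cn(CCCCOc2cc(=O)oc3ccccc23)nn1` has thiophen-2-yl in place of 2-methoxyphenyl on a double-bonded chain carbon bound to a double-bonded chain carbon. Going by the values given here, only one measured step bears on this place, a number 6 percentage points lower from compound 1 to compound 2 (within the scatter), and it exchanged one methoxy-bearing phenyl group for another. Among the compounds with values here, no measured compound carries thiophen-2-yl, so the evidence is thin and the range stays wide. With that single step inside the scatter, no step beyond the scatter is expected in this assay. The estimated step is a number 1 percentage points higher from compound 2 to compound 3 (within the scatter). For compound 3 the expected value is 48%, with an estimated range of 30% to 65%.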

Compound 3, percent growth inhibition at one concentration: 40%
The estimate for compound 3 lay 8 percentage points above the measured number, within the range that was stated.
By their numbers in this assay, from the lowest: compounds 3, 2 and 1 (each within the scatter of the next, the first and the last beyond it).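

Exchanging the aryl group at this place for a five-membered sulfur-containing ring still leaves measurable growth inhibition in this assay: compound 3 gives 40%. Thiophen-2-yl in place of 2-methoxyphenyl gives a number 7 percentage points lower from compound 2 to compound 3 (within the scatter), while thiophen-2-yl in place of 3,4-dimethoxyphenyl gives a number 13 percentage points lower from compound 1 to compound 3 (beyond the scatter), the only step beyond the scatter so far at this position, so a change here can register in this read-out, though modestly. No supporting measurement is available to explain this difference.

Still open, on these data alone, is whether a pyridine ring, or a phenyl group carrying an amine or a carboxylic acid, on this double-bonded chain carbon would move the number further in either direction. The series also leaves open whether the step to thiophen-2-yl holds with a longer chain in place of the butyl linker.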